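Removing a fluorine from the weakest amide

The source may report more compounds than this note shows. Statements on the series, on what has been measured and on what is new or still open speak of the compounds shown alone.

Three compounds have been measured in a functional assay on HT-29 cells (Homo sapiens) for cytotoxicity, read by MTT assay, with a stated time of 72 h; on this read-out lower numbers stand for stronger inhibition and higher numbers for weaker inhibition:
compound 1 `Cc1cccc(Cl)c1NC(=O)CN1CCN(c2nnc(Cc3ccncc3)c3ccccc23)CC1` gives 22600 nM;
compound 2 `O=C(CN1CCN(c2nnc(Cc3ccncc3)c3ccccc23)CC1)Nc1cccc(F)c1` gives 6130 nM;
compound 3 `Cc1ccc(F)cc1NC(=O)CN1CCN(c2nnc(Cc3ccccc3)c3ccccc23)CC1` gives 171000 nM.

Compound 3 has the highest number of the three, so it is the least potent of this small set; its gap to compound 1 and its wider gap to compound 2 both lie beyond the usual scatter. Compound 4 `Cc1ccccc1NC(=O)CN1CCN(c2nnc(Cc3ccccc3)c3ccccc23)CC1` is the next compound to be tested in this assay. It differs from compound 3 in one place: hydrogen in place of fluoro on an aromatic carbon.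

Among the measured compounds shown here, only one measured step exists, a 3.7-fold lower number from compound 1 to compound 2 (0.57 log units; beyond the scatter), and it swaps the whole ring attached to the amide-type nitrogen rather than taking away a single fluoro, so it is at best a loose guide. For the measured compounds named here, no pair of measured compounds differs only by hydrogen in place of fluoro. The change from compound 3 to compound 4 is small, so the expected step in this assay is a 1.1-fold lower number from compound 3 to compound 4 (0.06 log units; within the scatter), which is not beyond the scatter. Compound 4 is therefore estimated to give 150000 nM, within a range from 50000 nM to 450000 nM.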

Compound 4, half-maximal inhibitory concentration: 113000 nM
Beside the measured number, compound 4's estimate is 1.3-fold (0.12 log units) above it, and the stated range covers the measured number.
By their numbers in this assay, from the lowest: compound 2; then compound 1; then compounds 4 and 3 (each within the scatter of the next).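

In this assay, removing the fluoro to turn 5-fluoro-2-methylphenyl into 2-methylphenyl gives a 1.5-fold lower number from compound 3 to compound 4 (0.18 log units; within the scatter) and nothing else in the molecule changes. Among the compounds shown here, this is the first measured step that isolates hydrogen in place of fluoro, whereas the earlier step swapped a whole ring and could not single out any one atom. On this aromatic carbon, para to a methyl group, the assay does not separate fluoro from hydrogen, so this fluorine shows no measurable contribution to the read-out in this pair. No outside measurement bears on this result, so it comes with no explanation.

The compounds shown leave open whether this carbon tolerates any substituent or only very small ones, since a group such as an amine or a carboxylic acid placed there could give a quite different number. They also leave open whether hydrogen in place of fluoro would be equally quiet in compound 2, where the fluorine sits on a 3-fluorophenyl ring and the rest of the molecule differs from compound 3.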